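Swapping a Cyclobutyl Ether for a Benzyl Ether

The source may report more compounds than this note shows. Statements on the series, on what has been measured and on what is new or still open speak of the compounds shown alone.

Three compounds share one core and differ only in the group carried on an oxygen on an aromatic ring. Compound 1 `CCN(CC)C(=O)Cc1c(-c2ccc(OC3CCC3)cc2)nn2c(C)cc(C)nc12` carries a cyclobutyl group there; in an assay on isolated protein (kidney, strain Wistar) for displacement of a labelled ligand from Translocator protein (Rattus norvegicus), read by scintillation counting, with a stated time of 90 min (a higher number here means a weaker inhibitor, a lower number a stronger inhibitor), compound 1 gives 0.86 nM, the lowest of the three numbers. Compound 2 `CCN(CC)C(=O)Cc1c(-c2ccc(OC3CCCC3)cc2)nn2c(C)cc(C)nc12` carries a cyclopentyl group and gives 1.5 nM, a step of a 1.7-fold higher number from compound 1 to compound 2 (0.24 log units; within the scatter). Compound 3 `CCN(CC)C(=O)Cc1c(-c2ccc(OCC3CCCCC3)cc2)nn2c(C)cc(C)nc12` carries a cyclohexylmethyl group and gives 3.6 nM, a step of a 4.2-fold higher number from compound 1 to compound 3 (0.62 log units; beyond the scatter), while the step from the cyclopentyl to the cyclohexylmethyl compound is a 2.4-fold higher number from compound 2 to compound 3 (0.38 log units; beyond the scatter).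

Compound 4 `CCN(CC)C(=O)Cc1c(-c2ccc(OCc3ccccc3)cc2)nn2c(C)cc(C)nc12` has not been measured. Its difference from compound 1 is benzyl in place of cyclobutyl on an oxygen on an aromatic ring. The nearest measured analogy is the step to compound 3, since benzyl and cyclohexylmethyl both set a six-membered ring one bond further out from the oxygen than the cyclobutyl group of compound 1. Given that compound 3 gave a 4.2-fold higher number from compound 1 to compound 3 (0.62 log units; beyond the scatter), a rise of modest size is expected for compound 4 as well, and the estimated step of a 2.9-fold higher number from compound 1 to compound 4 (0.46 log units; beyond the scatter) points to a weaker inhibitor than compound 1. Compound 4 is therefore expected to give about 2.5 nM in this assay, most likely between 1 nM and 6 nM.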

Compound 4, inhibition constant: 0.99 nM
Estimate against measurement, compound 4: 2.5-fold (0.40 log units) above; the measured number lies below the stated range.
By their numbers in this assay, from the lowest: compounds 1, 4 and 2 (each within the scatter of the next); then compound 3.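

In this assay, the step from cyclobutyl to benzyl on the oxygen is a 1.2-fold higher number from compound 1 to compound 4 (0.06 log units; within the scatter), and the step from cyclopentyl to benzyl is a 1.5-fold lower number from compound 2 to compound 4 (0.18 log units; within the scatter), so these three groups cannot be told apart here even though benzyl brings an aromatic ring to this position. Compound 3 and compound 4 differ only in the ring on the saturated chain carbon bound to the oxygen, and phenyl in place of cyclohexyl gives a 3.6-fold lower number from compound 3 to compound 4 (0.56 log units; beyond the scatter); at this position, then, a six-membered ring alone does not bring the rise seen for compound 3, and which six-membered ring it is matters. Nothing available here bears on why phenyl and cyclohexyl part in this way.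

From the compounds shown here alone, whether a pyridinylmethyl group, with a nitrogen in the ring, or a phenethyl group, with a longer chain, would stay level with compound 4 remains open. All these numbers also come from this assay alone, so how the four ethers behave in cells or in a living animal is open too.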